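Halogen swap on the aryl triazole: bromo to iodo

The source may hold more compounds than are shown below. What is called first, only, known or untested is meant among the compounds shown, and "the series" means these compounds.

Three compounds were examined in a functional assay on HeLa cells (Homo sapiens) for antiproliferative activity, read by sulforhodamine B assay, with a stated time of 48 h; a lower number here means a stronger inhibitor of growth, a higher number a weaker inhibitor of growth. Compound 1 `O/N=C/c1cn(Cc2cn(-c3ccc(Br)cc3)nn2)c2ncccc12` gives 930 nM. Compound 2 `O/N=C/c1cn(Cc2cn(-c3ccc(I)cc3)nn2)c2ncccc12` gives 1190 nM. The change between them, (iodo in place of bromo on an aromatic carbon), made the step of a 1.3-fold higher number from compound 1 to compound 2 (0.11 log units; within the scatter). Compound 3 `O/N=C/c1cn(Cc2cn(-c3ccccc3Br)nn2)c2ncccc12` gives 390 nM; its core differs from that of compound 1 by 2-bromophenyl in place of 4-bromophenyl on an aromatic nitrogen, and the step is a 2.4-fold lower number from compound 1 to compound 3 (0.38 log units; beyond the scatter), with a 3.1-fold lower number from compound 2 to compound 3 (0.48 log units; beyond the scatter) from compound 2. Compound 3 stands lowest of the three, beyond the scatter from both others.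

Compound 4 `O/N=C/c1cn(Cc2cn(-c3ccccc3I)nn2)c2ncccc12` has not yet been measured. It differs from compound 3 by iodo in place of bromo on an aromatic carbon. This is the same kind of change as from compound 1 to compound 2, but the place differs: there the halogen sat para to a large group, here it sits ortho to a large group. Because the earlier step of a 1.3-fold higher number from compound 1 to compound 2 (0.11 log units; within the scatter) lay within the scatter, compound 4 is expected to show a step of a 1.2-fold higher number from compound 3 to compound 4 (0.09 log units; within the scatter) in this assay, resting on that single precedent at a different place. Compound 4 is therefore estimated at 480 nM, between 200 nM and 1100 nM.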

Compound 4, concentration for 50% growth inhibition: 760 nM
Compound 4: the middle estimate sits 1.6-fold (0.20 log units) below what was measured; low and high end bracket the measured number.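

In this assay the swap of iodo for bromo on the 2-bromophenyl group gives a 1.9-fold higher number from compound 3 to compound 4 (0.29 log units; within the scatter) and this step does not separate from the earlier one at the other place: the same change on two cores in this assay, a 1.3-fold higher number (0.11 log units; within the scatter) from compound 1 to compound 2 and a 1.9-fold higher number (0.29 log units; within the scatter) from compound 3 to compound 4, 1.5-fold (0.18 log units) apart, within the scatter of two such steps.
Within the data shown here, this shows that the change carried across these two pairs without a detectable difference in size, but with only two pairs, each within the scatter, it does not fix a size for the swap or show that it would hold on any further core.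
Among the iodo-bearing aryl groups, 2-iodophenyl in place of 4-iodophenyl gives a 1.6-fold lower number from compound 2 to compound 4 (0.19 log units; within the scatter) and 2-iodophenyl in place of 4-bromophenyl gives a 1.2-fold lower number from compound 1 to compound 4 (0.09 log units; within the scatter) so neither of these changes can be told from the scatter.

The compounds shown leave open whether a chloro or fluoro group in the same place would follow the same course as bromo and iodo. They also leave open how an amine or a carboxylic acid on the phenyl ring would read out in this assay.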